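Third methoxy on compound 3: expected change

The source may hold more compounds than are shown below. What is called first, only, known or untested is meant among the compounds shown, and "the series" means these compounds.

Measured so far in an ADME assay on CCRF-CEM cells (Homo sapiens) for antiproliferative activity, with a stated time of 48 h; on this read-out higher numbers stand for weaker inhibition and lower numbers for stronger inhibition:
compound 1 `C=C(Br)C(=O)Nc1ccc(C(=O)/C=C/c2ccc(OC)c(OC)c2OC)cc1`: 840 nM
compound 2 `COc1cccc(/C=C/C(=O)c2ccc(N)cc2)c1`: 23000 nM
compound 3 `COc1cccc(/C=C/C(=O)c2ccc(N)cc2)c1OC`: 7600 nM

Of these three numbers, compound 3 at 7600 nM is the second highest. Compound 4 `COc1ccc(/C=C/C(=O)c2ccc(N)cc2)c(OC)c1OC` differs from compound 3 as follows: methoxy in place of hydrogen on an aromatic carbon, which is methoxy in place of hydrogen on an aromatic carbon. Within the data shown here, the only measured step of this kind is a 3.0-fold lower number from compound 2 to compound 3 (0.48 log units; beyond the scatter), modest and beyond the scatter. A similar modest step towards a lower number is therefore expected in this assay, though one step is thin support. The expected change is a 2.5-fold lower number from compound 3 to compound 4 (0.40 log units; beyond the scatter). Compound 4 is estimated at 3000 nM, with an expected range of 1000 nM to 8000 nM.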

Compound 4, half-maximal inhibitory concentration: 9700 nM
Beside the measured number, compound 4's estimate is 3.2-fold (0.51 log units) below it; measured number above the stated range.
By their numbers in this assay, from the lowest: compound 1; then compounds 3 and 4 (each within the scatter of the next); then compound 2.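

In (the first use prints in full) this assay methoxy in place of hydrogen at this place, para to a large group, gives only a step within the scatter (a 1.3-fold higher number from compound 3 to compound 4 (0.11 log units; within the scatter)), unlike the earlier methoxy step (a 3.0-fold lower number from compound 2 to compound 3 (0.48 log units; beyond the scatter)), so the gain does not simply add up across the series. The far larger difference lies on the nitrogen, where hydrogen in place of (1-bromoethenyl)carbonyl gives a large step (a 12-fold higher number from compound 1 to compound 4 (1.06 log units; beyond the scatter)). Nothing at hand accounts for either step.

From the compounds shown here alone, whether a plain acryloyl or an acetyl on that nitrogen, without bromine, would keep the lower number of compound 1 remains open. Also open, going by these compounds, is whether a hydroxy or a fluorine in place of this methoxy would give a step beyond the scatter.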